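The source may report more compounds than this note shows. Statements on the series, on what has been measured and on what is new or still open speak of the compounds shown alone.

The study concerns a set of compounds sharing one core, all carried through an ADME assay on HEK-293T cells (Homo sapiens) for cytotoxicity, read by MTT assay, with a stated time of 72 h, tested at 50 uM; a higher number here means more inhibition at the concentration tested (going by the name of the read-out), a lower number less inhibition. In this assay compound 1 `CCc1nnc(NC(=O)Cn2c(-c3ccccc3)cc(-c3ccccc3)c2-c2ccco2)s1` gives 81%. In this assay, going by the values given here, compound 2 `O=C(Cn1c(-c2ccccc2)cc(-c2ccccc2)c1-c1ccco1)Nc1ccccn1` gives 69.4%, the lowest of the two numbers known so far; the single measured step, a number 11.6 percentage points lower from compound 1 to compound 2 (beyond the scatter), separates it from compound 1. The account now turns to compound 3 `O=C(Cn1c(-c2ccccc2)cc(-c2ccccc2)c1-c1ccccc1)Nc1ccccn1`, which has not yet been measured in this assay. It differs from compound 2 in one place: phenyl in place of furan-2-yl on an aromatic carbon. Among the compounds with values here, no measured step touches this place. Within the data shown here, the only step known, a number 11.6 percentage points lower from compound 1 to compound 2 (beyond the scatter), concerns the group on the amide-type nitrogen, not an aromatic carbon of the shared core, so it gives no direct guide to the present exchange, and it was itself only modest. With nothing pointing in either direction, the expected step of a number 1.4 percentage points lower from compound 2 to compound 3 (within the scatter) is none beyond the scatter. Compound 3 is therefore estimated at 68% in this assay, with a range from 50% to 84%.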

Compound 3, a percentage reported as inhibition, at one concentration (the size of the read-out at that concentration, not a potency): 62.9%
Estimate against measurement, compound 3: 5.1 percentage points above; the range from low to high includes it.
By their numbers in this assay, from the lowest: compounds 3 and 2 (each within the scatter of the next); then compound 1.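

In this assay the exchange of furan-2-yl for phenyl, on the aromatic carbon next to the ring nitrogen, comes to a number 6.5 percentage points lower from compound 2 to compound 3 (within the scatter), so with the pyridin-2-yl group held on the amide-type nitrogen, compound 2 and compound 3 cannot be told apart at this position. Going by these compounds alone, this is the first reading at this place, and it shows that a six-membered aromatic ring of carbon only can stand here in place of a five-membered aromatic ring with one oxygen, with no difference that rises above the scatter, whereas the step at the amide-type nitrogen, a number 11.6 percentage points lower from compound 1 to compound 2 (beyond the scatter), does rise above it. Nothing measured on these compounds accounts for either result.

The compounds shown leave open whether a group of another kind at this aromatic carbon, such as an amine, a carboxylic acid or a longer alkyl chain, would stand apart from furan-2-yl or phenyl. They also leave open whether phenyl in place of furan-2-yl would read the same with 5-ethyl-1,3,4-thiadiazol-2-yl on the amide-type nitrogen.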